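A few compounds are considered here, and "the series" means these few. Any claim that something is new, unique, unknown or untested is made for them only; others in the source may bear on it.

Of the compounds shown here, three have so far been measured in a functional assay on cells (Endothelial cell, Bos taurus) for antiproliferative activity; on this read-out lower numbers stand for stronger inhibition and higher numbers for weaker inhibition. Compound 3 `COc1ccc(/C(F)=C\c2cc(OC)c(OC)c(OC)c2)cc1N` gives 2100 nM in this assay. Compound 1 `COc1ccc(/C(F)=C\c2cc(OC)c(OC)c(OC)c2)cc1O` gives 4700 nM, and compound 2 `COc1ccc(/C(F)=C(/F)c2cc(OC)c(OC)c(OC)c2)cc1N` gives 3600 nM. Compound 1 differs from compound 3 by one change, (hydroxy in place of amino on an aromatic carbon), and this produced a 2.2-fold higher number from compound 3 to compound 1 (0.35 log units; beyond the scatter). The numbers of compound 2 and compound 1, and likewise of compound 2 and compound 3, lie within the usual scatter of each other, so no order among them is drawn. Compound 2 and compound 3 differ in their cores, and the difference between the two cores is not broken down here.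

The unmeasured compound 4 `COc1ccc(/C(F)=C(/F)c2cc(OC)c(OC)c(OC)c2)cc1O` is built from compound 2 by hydroxy in place of amino on an aromatic carbon, the same change at the same place as the one between compound 3 and compound 1, which occurs twice among these compounds. Compound 4 is expected to show a 2.2-fold higher number from compound 2 to compound 4 (0.34 log units; beyond the scatter) because the same change gave a 2.2-fold higher number from compound 3 to compound 1 (0.35 log units; beyond the scatter). Compound 4 is therefore estimated at 7800 nM in this assay, with a range from 3800 nM to 16000 nM.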

Compound 4, half-maximal inhibitory concentration: 4600 nM
The estimate for compound 4 lay 1.7-fold (0.23 log units) above the measured number; the range from low to high includes it.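

In this assay, hydroxy in place of amino on the core carrying the second fluorine gives a 1.3-fold higher number from compound 2 to compound 4 (0.11 log units; within the scatter). Set beside the earlier step on the other core, this step does not differ from it by more than two such measurements would be expected to vary: the same change on two cores in this assay, a 2.2-fold higher number (0.35 log units; beyond the scatter) from compound 3 to compound 1 and a 1.3-fold higher number (0.11 log units; within the scatter) from compound 2 to compound 4, 1.8-fold (0.24 log units) apart, within the scatter of two such steps The change can therefore be carried between these two cores without any detectable difference in its effect, but with only one step beyond the scatter and one within it, these two pairs neither establish that the change acts identically on both cores nor give a rule for the series.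

The compounds shown leave open how other groups at this place on the ring, such as a carboxylic acid, a nitrile or a methyl group, would read in this assay. They also leave open whether hydroxy in place of amino would give a similar step on a core with no fluorine on its central double bond.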